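Swapping Cyclohexylmethyl for Phenyl on a Shared Core

A few compounds are considered here, and "the series" means these few. Any claim that something is new, unique, unknown or untested is made for them only; others in the source may bear on it.

Measured compounds:
Compound 1 `O=C(O)c1ccccc1-c1ccc(CCc2ncc(Cc3ccccc3Cl)[nH]2)cc1` gives 22 nM in an in vitro functional assay on cells for agonist activity at Bombesin receptor subtype-3 (Mus musculus), read by luminescence and calcium flux; on this read-out higher numbers stand for an effect only at larger amounts of compound and lower numbers for an effect already at smaller amounts.
Compound 2 `Cc1cccc(Cc2cnc(CCc3ccc(-c4ccccc4C(=O)O)cc3)[nH]2)c1` gives 75 nM.
Compound 3 `O=C(O)c1ccccc1-c1ccc(CCc2ncc(CCC3CCCCC3)[nH]2)cc1` gives 33 nM.

Compound 3 holds the second highest of the three numbers. Its nearest neighbour is compound 1, separated only by a 1.5-fold higher number from compound 1 to compound 3 (0.18 log units; within the scatter), a gap within the usual scatter. Compound 2 lies further away, as seen in a 2.3-fold lower number from compound 2 to compound 3 (0.36 log units; beyond the scatter).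

Compound 4 `O=C(O)c1ccccc1-c1ccc(CCc2ncc(Cc3ccccc3)[nH]2)cc1` is not yet measured. Its difference from compound 3 is phenyl in place of cyclohexylmethyl on a saturated chain carbon bound to an aromatic carbon. Going by the values given here, two measured steps bear on this change, since both lead from an aromatic ring at the same place to cyclohexylmethyl: a 1.5-fold higher number from compound 1 to compound 3 (0.18 log units; within the scatter) stays within the scatter, while a 2.3-fold lower number from compound 2 to compound 3 (0.36 log units; beyond the scatter) is modest but beyond it. Compound 4 moves the other way, from the saturated ring back to an aromatic one, so a modest rise in the number or no change beyond the scatter is expected in this assay.

Compound 4 is therefore expected to give about 45 nM, with a likely range from 15 nM to 130 nM. This estimate corresponds to an expected step of a 1.4-fold higher number from compound 3 to compound 4 (0.13 log units; within the scatter).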

Compound 4, half-maximal effective concentration: 11 nM
For compound 4 the middle estimate is 4.1-fold (0.61 log units) above the measured one; measured number below the stated range.
By their numbers in this assay, from the lowest: compounds 4, 1 and 3 (each within the scatter of the next, the first and the last beyond it); then compound 2.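

Going by these compounds alone, the unsubstituted ring now gives a reference point that the earlier compounds lacked: in this assay, the change from 2-cyclohexylethyl to benzyl gives a 3.0-fold lower number from compound 3 to compound 4 (0.48 log units; beyond the scatter), so here a saturated ring does not match a bare aromatic one. Substituents on that aromatic ring also separate clearly: removing the methyl gives a 6.8-fold lower number from compound 2 to compound 4 (0.83 log units; beyond the scatter), whereas removing the chloro gives a 2.0-fold lower number from compound 1 to compound 4 (0.30 log units; within the scatter), so the chloro has no effect beyond the scatter. Within the data shown here, the methyl is the only one of these two ring substituents whose presence raises the number beyond the scatter.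

Nothing available explains these steps. Ring type and chain length change together in this swap, so 2-phenylethyl would be needed to separate them, and an amine on the aromatic ring remains an open question.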